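4-Methylpiperazin-1-yl Replaces (Dimethylcarbamoyl)methyl on Compound 2

A few compounds are considered here, and "the series" means these few. Any claim that something is new, unique, unknown or untested is made for them only; others in the source may bear on it.

Compound 2 `CN(C)C(=O)Cc1sc(NC(=O)c2ccncc2)nc1-c1ccncc1` gives 38.1% in an assay on isolated protein for inhibition of Rho-associated protein kinase 2 (Homo sapiens), read by ELISA, with a stated time of 30 min, tested at 10 uM, in the presence of a further agent that is not named here (on this read-out lower numbers stand for less inhibition and higher numbers for more inhibition at the one concentration tested (going by the name of the read-out)), the second highest of three numbers: compound 1 `CN(C)C(=O)Cc1sc(NC(=O)C2COc3ccccc3O2)nc1-c1ccncc1` gives 56.9%, and compound 3 `O=C(Nc1nc(-c2cccnc2)c(CN2CCCCC2)s1)c1cccnc1` gives 28.5%, the latter within the scatter of compound 2. For the measured compounds named here, the only measured step, a number 18.8 percentage points lower from compound 1 to compound 2 (beyond the scatter), changes the substituent on the carbonyl carbon, not the aromatic carbon of the shared core. Compound 4 `CN1CCN(c2sc(NC(=O)c3ccncc3)nc2-c2ccncc2)CC1` differs from compound 2 only at that aromatic carbon: 4-methylpiperazin-1-yl in place of (dimethylcarbamoyl)methyl on an aromatic carbon. Going by the values given here, no measured step touches this position, so the data give no direction for it. The step is therefore expected to be a number 2.1 percentage points lower from compound 2 to compound 4 (within the scatter), within the scatter. Compound 4 is estimated at 36%, with a range from 16% to 56%.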

Compound 4, a percentage reported as inhibition, at one concentration (the size of the read-out at that concentration, not a potency): 34.3%
Compound 4: middle estimate off by 1.7 percentage points, on the high side, within the range that was stated.
By their numbers in this assay, from the lowest: compounds 3, 4 and 2 (each within the scatter of the next); then compound 1.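

For the compounds shown here, with a number 3.8 percentage points lower from compound 2 to compound 4 (within the scatter) in this assay, this is the first measured change on the aromatic carbon next to the ring sulfur. At this position, the ring-bearing 4-methylpiperazin-1-yl and the open-chain (dimethylcarbamoyl)methyl are not told apart by this read-out. Nothing available explains this outcome. From the compounds shown here alone, it remains open whether a carboxylic acid or a primary amine on this carbon would shift the number beyond the scatter. Going by these compounds, it is also open whether 4-methylpiperazin-1-yl would behave the same with the 2,3-dihydro-1,4-benzodioxin-2-yl group of compound 1 on the carbonyl carbon.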